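Compound 4: methyl removed from the aromatic nitrogen

The source may report more compounds than this note shows. Statements on the series, on what has been measured and on what is new or still open speak of the compounds shown alone.

Three compounds in this series have been run in an ADME assay on microsomes from liver (Mus musculus) for metabolic stability, read by LC-MS, with a stated time of 30 min, tested at 1 uM; on this read-out higher numbers stand for a more stable compound and lower numbers for a less stable compound. Compound 1 `Cn1c(C(=O)NCc2ccc(S(=O)(=O)c3ccccc3)cc2)cc2cnccc21` gives 34% in this assay, compound 2 `O=C(NCc1ccc(S(=O)(=O)c2ccccc2)cc1)c1cc(-c2cccnc2)[nH]n1` gives 42%, and compound 3 `O=C(NCc1ccc(S(=O)(=O)N2CCCCC2)cc1)c1ccc2nc[nH]c2c1` gives 16%. Compound 1 holds the second highest of the three numbers: compound 2 sits closest to it, a few points higher and within the scatter of this assay, while compound 3 lies furthest away, lower by a margin beyond the scatter.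

Compound 4 `O=C(NCc1ccc(S(=O)(=O)c2ccccc2)cc1)c1cc2cnccc2[nH]1` has not been measured yet. It differs from compound 1 in one place: hydrogen in place of methyl on an aromatic nitrogen. For the measured compounds named here, no measured pair differs by this change, so the size of the step cannot be taken from existing numbers. A small gain in the fraction remaining is expected for compound 4 because compound 2 gives 42% in this assay, and compound 2 is the closest measured analogue without a methyl on such a nitrogen. The estimated step from compound 1 to compound 4 in this assay is a number 10 percentage points higher from compound 1 to compound 4 (within the scatter). For compound 4 the expected value in this assay is 44%, with a range from 26% to 62%.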

Compound 4, percent of the compound remaining: 54%
Compound 4: middle estimate off by 10 percentage points, on the low side, and the stated range covers the measured number.
By their numbers in this assay, from the lowest: compound 3; then compounds 1 and 2 (each within the scatter of the next); then compound 4.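

In this assay, for the compounds shown here, hydrogen in place of methyl on the aromatic nitrogen gives a number 20 percentage points higher from compound 1 to compound 4 (beyond the scatter) and is the first single-place change that can be read directly. The removal of a single heavy atom, on an aromatic nitrogen of a five-membered aromatic ring next to the ring atom that bears a large group, is thus enough to move the fraction remaining beyond the usual scatter, so this position matters for the read-out on the core of compound 1. No measurement available here accounts for the step.

This single pair leaves open whether the same change gives a similar step on another core. Going by these compounds, how an ethyl, a longer chain or a chain ending in an amine on this nitrogen would compare with hydrogen and methyl also remains open.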